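Aryl variation on the saturated ring carbon: toward compound 3

A few compounds are considered here, and "the series" means these few. Any claim that something is new, unique, unknown or untested is made for them only; others in the source may bear on it.

Measured so far:
compound 1 `COc1ccc(C2C(C#N)=C(N)N(c3ccc(S(N)(=O)=O)cc3)C3=C2C(=O)CCC3)cc1` — 90%
compound 2 `N#CC1=C(N)N(c2ccc(S(N)(=O)=O)cc2)C2=C(C(=O)CCC2)C1c1c(O)ccc2ccccc12` — 5%

In a functional assay on Ehrlich cells (Mus musculus) for antiproliferative activity, read by trypan blue exclusion, with a stated time of 2 h, tested at 50 ug/mL (on this read-out lower numbers stand for a weaker effect and higher numbers for a stronger effect at the one concentration tested), compound 1 gives 90% and compound 2 gives 5%; of these two numbers compound 2 stands lowest, with compound 1 as its nearest neighbour. Compound 3 `Cc1ccoc1C1C(C#N)=C(N)N(c2ccc(S(N)(=O)=O)cc2)C2=C1C(=O)CCC2` differs from compound 2 by 3-methylfuran-2-yl in place of 2-hydroxynaphthalen-1-yl on a saturated ring carbon. Among the compounds with values here, the only measured step at the same saturated ring carbon is a number 85 percentage points lower from compound 1 to compound 2 (beyond the scatter), a large fall. Within the data shown here, no measured pair shows what a 3-methylfuran-2-yl group does there, so the direction remains open. For compound 3 a step of a number 45 percentage points higher from compound 2 to compound 3 (beyond the scatter) is expected. Compound 3 is estimated at 50%, within 10% to 90%.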

Compound 3, a percentage reported as activity, at one concentration (the size of the read-out at that concentration, not a potency): 40%
Compound 3: middle estimate off by 10 percentage points, on the high side; low and high end bracket the measured number.
By their numbers in this assay, from the lowest: compound 2; then compound 3; then compound 1.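

In this assay, the saturated ring carbon now shows a third level, with 3-methylfuran-2-yl apart from both earlier groups: a number 35 percentage points higher from compound 2 to compound 3 (beyond the scatter), and a number 50 percentage points lower from compound 1 to compound 3 (beyond the scatter). A single five-membered aromatic ring with 1 hetero atom therefore retains part of the effect seen with 4-methoxyphenyl, though not all of it. No evidence on hand accounts for this order.

Open is what the methyl group on the furan contributes, since no unsubstituted furan-2-yl compound is shown. As far as these compounds go, the effect of a phenyl ring carrying an amine or a carboxylic acid at this carbon also remains open.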